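Cyclopropyl Replaces Pyrrolidinyl on the Ring Nitrogen

The compounds below may be only part of what the source reports. "The series", "measured", "known", "first", "only" and "open" are said of these compounds alone.

Compound 1 `O=C(Cc1nn(C2CCNC2)c(=O)c2ccccc12)Nc1ccc(OC(F)(F)F)c(Cl)c1` was examined in a functional assay on CHO cells for antagonist activity at sphingosine 1-phosphate receptor 2 (Homo sapiens), read by GTPgammaS binding (on this read-out lower numbers stand for stronger inhibition and higher numbers for weaker inhibition), where compound 1 gives 42 nM. Two further compounds were measured in the same way. Compound 2 `COc1cc(OC)c(NC(=O)Cn2nc(CC(=O)O)c3ccccc32)cc1Cl` gives 8980 nM in this assay, and compound 3 `COc1cc(OC)c(NC(=O)Cc2nn(CC(=O)O)c(=O)c3ccccc23)cc1Cl` gives 464 nM in this assay. Compound 1 therefore shows the lowest number of the three; the nearest, compound 3, lies well beyond the usual scatter, and compound 2 lies further still. Neither of these two differs from compound 1 in only one place, so their values say nothing about any single structural change.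

Compound 4 `O=C(Cc1nn(C2CC2)c(=O)c2ccccc12)Nc1ccc(OC(F)(F)F)c(Cl)c1` has not yet been measured. It differs from compound 1 in one place: cyclopropyl in place of pyrrolidin-3-yl on an aromatic nitrogen. Going by the values given here, no measured pair shows this exchange, so its effect can only be guessed. The account expects a moderate step towards a higher number, estimated as a 3.6-fold higher number from compound 1 to compound 4 (0.55 log units; beyond the scatter) in this assay. For compound 4 the estimated value is 150 nM, with an expected range from 40 nM to 600 nM.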

Compound 4, half-maximal inhibitory concentration: 565 nM
Compound 4: the middle estimate sits 3.8-fold (0.58 log units) below what was measured; low and high end bracket the measured number.
By their numbers in this assay, from the lowest: compound 1; then compounds 3 and 4 (each within the scatter of the next); then compound 2.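

Going by these compounds alone, on the aromatic nitrogen of the shared core, replacing pyrrolidin-3-yl with cyclopropyl gives a 13-fold higher number from compound 1 to compound 4 (1.13 log units; beyond the scatter) in this assay, a large step and the first direct reading at this position. The exchange takes away the ring nitrogen, with its 1 hydrogen-bond donor and 1 hydrogen-bond acceptor, and also goes from a five-membered to a three-membered ring, so two things change in this single step. Nothing measured here explains the size of the step.

The compounds shown leave open whether the ring nitrogen or the ring size matters more: a cyclopentyl group, with carbon only, or an open-chain aminoethyl group on the same nitrogen would help separate the two. On these data alone, whether a piperidin-4-yl ring would hold the number of compound 1 also remains open.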